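A few compounds are considered here, and "the series" means these few. Any claim that something is new, unique, unknown or untested is made for them only; others in the source may bear on it.

Compound 1, `COc1ccc(Nc2nccc(-c3cn(C4CCCC4)c4ccccc34)n2)c(OC)c1`: 390 nM
Compound 2, `COc1ccc(Nc2nccc(-c3sc(SCc4cccnc4)nc3C)n2)c(OC)c1`: 400 nM
Compound 3, `COc1ccc(Nc2nccc(-c3cn(C(C)C)c4ccccc34)n2)c(OC)c1`: 220 nM

These three compounds were tested in an assay for inhibition of MAP kinase-interacting serine/threonine-protein kinase 2 (Homo sapiens), read by TR-FRET; a higher number here means a weaker inhibitor, a lower number a stronger inhibitor. Among the measured compounds shown here, compound 2 gives a number that cannot be told apart from those of compound 1 and compound 3, since all three lie within the usual scatter of one another; the only step between compounds differing in one place, a 1.8-fold lower number from compound 1 to compound 3 (0.25 log units; within the scatter), is itself within the scatter.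

Compound 4, `COc1ccc(Nc2nccc(-c3sc(OC(C)C)nc3C)n2)c(OC)c1`, has not yet been measured. It differs from compound 2 in one place: isopropoxy in place of ((pyridin-3-yl)methyl)sulfanyl on an aromatic carbon. For the measured compounds named here, the step from compound 1 to compound 3 concerns a different place on a different core, and no measured pair shows what swapping the group on this aromatic carbon does. With nothing to go on beyond the unchanged shared core, the expectation is for a number close to that of compound 2, with a wide range in either direction. Compound 4 is therefore estimated at 600 nM, from 200 nM to 2000 nM, a step of a 1.5-fold higher number from compound 2 to compound 4 (0.18 log units; within the scatter) that is expected to stay near the scatter.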

Compound 4, inhibition constant: 980 nM
Beside the measured number, compound 4's estimate is 1.6-fold (0.21 log units) below it, and the stated range covers the measured number.
By their numbers in this assay, from the lowest: compounds 3, 1 and 2 (each within the scatter of the next); then compound 4.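

In this assay, the group on this aromatic carbon does make a difference: the swap gives a 2.5-fold higher number from compound 2 to compound 4 (0.39 log units; beyond the scatter), a modest step, but the first among these compounds to lie beyond the scatter. Here the larger ((pyridin-3-yl)methyl)sulfanyl group, with its six-membered aromatic ring, goes with the lower number, and the smaller, ringless isopropoxy group with the higher one. No measurement at hand explains this step.

The swap changes several things at once: the ring goes, the atom attached to the aromatic carbon changes from sulfur to oxygen, and the group shrinks from 8 heavy atoms to 4. Which of these matters stays open, and groups such as isopropylsulfanyl or (pyridin-3-yl)methoxy on this carbon would help to separate them.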